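Urea and thiourea benzimidazole analogues against HT-29 cells

The source may hold more compounds than are shown below. What is called first, only, known or untested is meant among the compounds shown, and "the series" means these compounds.

Compound 1: `Cc1ccc(NC(=S)NC(=O)c2ccc(OCc3ccc(F)cc3)cc2)cc1-c1nc2ccccc2[nH]1` — 1910 nM
Compound 2: `Cc1ccc(NC(=O)NC(=O)c2ccc(OCc3ccccc3F)cc2)cc1-c1nc2ccccc2[nH]1` — 760 nM

Of the compounds shown here, two have been measured in a functional assay on HT-29 cells (Homo sapiens) for inhibition, read by MTT assay, with a stated time of 48 h; a lower number here means a stronger inhibitor, a higher number a weaker inhibitor. Compound 1 gives 1910 nM in this assay, while compound 2 gives 760 nM. Compound 2 thus holds the lower of the two numbers, with compound 1 lying beyond the scatter above it; the two structures differ in more than one place, so nothing more than the two values themselves can be read from this pair.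

Compound 3, `Cc1ccc(NC(=O)NC(=O)c2ccc(OCc3ccc(Cl)cc3Cl)cc2)cc1-c1nc2ccccc2[nH]1`, has not yet been measured. It differs from compound 2 in one place: 2,4-dichlorophenyl in place of 2-fluorophenyl on a saturated chain carbon bound to an oxygen on an aromatic ring. Going by the values given here, no measured pair shows the effect of such a change on the shared core, so the expectation rests on compound 2 alone. Compound 3 is expected to stay close to compound 2, with no step beyond the scatter in this assay, a 1.2-fold lower number from compound 2 to compound 3 (0.07 log units; within the scatter). Compound 3 is estimated at 650 nM, within a range from 220 nM to 2000 nM.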

Compound 3, half-maximal inhibitory concentration: 2620 nM
Compound 3: middle estimate off by 4.0-fold (0.61 log units), on the low side, and the stated range ends below it.
By their numbers in this assay, from the lowest: compound 2; then compounds 1 and 3 (each within the scatter of the next).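

Going by these compounds alone, exchanging 2-fluorophenyl for 2,4-dichlorophenyl on a saturated chain carbon bound to an oxygen on an aromatic ring gives, in this assay, a 3.4-fold higher number from compound 2 to compound 3 (0.54 log units; beyond the scatter) and so provides the first direct reading of this position. The step is modest but beyond the scatter, so the position is not indifferent to this change, and the 2-fluorobenzyl group of compound 2 gives the stronger inhibitor of this pair. Nothing available accounts for the step.

A single exchange that removes one fluorine and brings in two chlorines cannot show which of these differences matters. On these data alone, it also remains open how an unsubstituted phenyl, a methoxyphenyl or a longer chain would read at this place, and whether the same change would run the same way on the thiourea of compound 1.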